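Diacylhydrazine in place of arylhydrazide on a sulfonamide core

The compounds below may be only part of what the source reports. "The series", "measured", "known", "first", "only" and "open" are said of these compounds alone.

Compound 1 `O=C(NNc1cccc(Cl)c1)c1cccc(NS(=O)(=O)c2cnc(O)nc2O)c1`: 7760 nM
Compound 2 `Cc1ccc(C(=O)NNC(=O)c2ccc(NS(=O)(=O)c3cnc(O)nc3O)cc2)cc1`: > 20000 nM

In a functional assay on MDA-MB-231 cells (Homo sapiens) for antiproliferative activity, read by MTT assay, with a stated time of 24 h (a higher number here means a weaker inhibitor, a lower number a stronger inhibitor), compound 1 gives 7760 nM. Among the compounds with values here, that is the only number measured here. For compound 2 this assay returns > 20000 nM, which is a limit of the assay and not a number; the limit of > 20000 nM in this assay, at which 1 of the 2 values shown sits, describes it. Within the data shown here, no two measured compounds differ in only one place, so no step between them is available.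

Compound 3 `O=C(NNC(=O)c1ccccc1Cl)c1cccc(NS(=O)(=O)c2cnc(O)nc2O)c1` has not yet been measured. It differs from compound 1 in one place: (2-chlorophenyl)carbonyl in place of 3-chlorophenyl on an amine nitrogen. Compound 2 carries a carbonyl on the same kind of nitrogen and reached only a limit, while compound 1 sits at a number, so for compound 3 the expected step of a 1.9-fold higher number from compound 1 to compound 3 (0.29 log units; within the scatter) goes toward a weaker inhibitor and lies beyond the scatter. Compound 3 is therefore estimated at 15000 nM, between 5000 nM and 40000 nM.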

Compound 3, half-maximal inhibitory concentration: 2360 nM
For compound 3 the middle estimate is 6.4-fold (0.80 log units) above the measured one; measured number outside the range, below it.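

At the amine nitrogen whose other neighbour is an amide-type nitrogen, (2-chlorophenyl)carbonyl in place of 3-chlorophenyl gives, in this assay, a 3.3-fold lower number from compound 1 to compound 3 (0.52 log units; beyond the scatter), a move toward a stronger inhibitor. Within the data shown here, this is the first step available, and it shows that a carbonyl on this nitrogen can go with a measured effect on these cells. Compound 2 also carries a carbonyl on this kind of nitrogen, but it differs from compound 3 in more than one place, and its value is a limit of the assay and not a number, so it cannot be read against this step: the limit of > 20000 nM in this assay, at which 1 of the 3 values shown sits.

The step brings in the carbonyl and a different chlorophenyl together, and the compounds shown do not separate the two. From the compounds shown here alone, how an unsubstituted benzoyl group or a methoxy group on this ring would read remains open.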